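Tetrazolyl in place of methoxy: solubility outlook

This account rests on a few compounds, and the source may have more. Where it says the series, first, only, none or still open, it means among the compounds named here.

Compound 1 `COc1ccnc(Nc2cc3[nH]c(-c4cccc(C(F)(F)F)c4)nc3cn2)c1` carries a methoxy group on its six-membered aromatic ring with 1 nitrogen. In a physicochemical assay for solubility, using the shake flask method, measured as kinetic solubility, with a stated time of 20 h, at pH 2 (a lower number here means a less soluble compound, a higher number a more soluble compound), compound 1 gives < 5000 nM, which is a limit of the assay and not a number. Compound 2 `COc1ccc(Nc2cc3[nH]c(-c4cccc(C(F)(F)F)c4)nc3cn2)nc1` is the near neighbour, with 5-methoxypyridin-2-yl in place of 4-methoxypyridin-2-yl on a nitrogen on an aromatic ring. In this assay compound 2 gives < 5000 nM, again a limit. The step that the two limits leave unreadable from compound 1 to compound 2 therefore cannot be read in size or direction, and the limit of < 5000 nM in this assay, at which 2 of the 2 values shown sit, is all that the two measured values show.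

Compound 3 `FC(F)(F)c1cccc(-c2nc3cnc(Nc4cc(-c5nnn[nH]5)ccn4)cc3[nH]2)c1` differs from compound 1 by 1H-tetrazol-5-yl in place of methoxy on an aromatic carbon, meta to a large group and opposite the ring nitrogen. Going by the values given here, no measured step bears directly on this exchange; the only step recorded is unreadable because of a step that the two limits leave unreadable from compound 1 to compound 2. With compound 1 sitting at a limit, the expectation for compound 3 is a step that the limit leaves unreadable from compound 1 to compound 3, with no direction secured beyond the scatter. Compound 3 is estimated at 3000 nM, within 500 nM to 20000 nM, and a limit read-out remains likely.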

Compound 3, solubility: < 5000 nM
Compound 3: only a limit was reported; the forecaster's own chance of this, stated with the estimate: 60%; the middle value is on the limit's open side.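

Compound 3 gives only a limit in this assay, as do compound 1 and compound 2, so no step from compound 1 to compound 3 can be read: the limit of < 5000 nM in this assay, at which 3 of the 3 values shown sit.

The compounds shown leave open where each of the three truly lies relative to that limit, and whether 1H-tetrazol-5-yl in place of methoxy shifts the read-out at all.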